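A few compounds are considered here, and "the series" means these few. Any claim that something is new, unique, unknown or untested is made for them only; others in the source may bear on it.

Measured compounds and their values:
- compound 1 `COC(=O)c1cc(-c2csc(N/N=C/c3cccs3)n2)ccc1OCc1ccccc1` with 94.9% in a functional assay, read by spectrophotometry, with a stated time of 15 min, tested at 40 ug/mL; a lower number here means a weaker effect, a higher number a stronger effect of the compound at the concentration tested
- compound 2 `Clc1ccc(-c2csc(N/N=C/c3cccs3)n2)cc1` with 96% in this assay
- compound 3 `Fc1ccc(-c2csc(N/N=C/c3ccc(Cl)cc3Cl)n2)cc1` with 93.3% in this assay

All three compounds share the same core and were read in this assay at a single concentration, so the numbers say how strong or weak the effect of each compound is at that concentration and nothing more. Compound 3 has the lowest of the three numbers, yet its distance to compound 1 and to compound 2 lies within the usual scatter of this kind of measurement, so the three values cannot be ordered against one another. For the measured compounds named here, no step between two measured compounds that differ in one place is available, so no measured step guides the next one.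

Compound 4 `Cc1ccc(-c2csc(N/N=C/c3ccc(Cl)cc3Cl)n2)cc1` has not yet been measured in this assay. Compared with compound 3, the change is methyl in place of fluoro on an aromatic carbon. The shared core and the remainder of the molecule stay as in compound 3. Since the three measured values sit close together near the top of the scale, the step from compound 3 to compound 4 is expected to be a number 1.3 percentage points lower from compound 3 to compound 4 (within the scatter), that is, none beyond the scatter. Compound 4 is therefore estimated at 92%, with a range from 80% to 98%.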

Compound 4, a percentage reported as inhibition, at one concentration (the size of the read-out at that concentration, not a potency): 86.2%
The estimate for compound 4 lay 5.8 percentage points above the measured number, within the range that was stated.
By their numbers in this assay, from the lowest: compounds 4, 3, 1 and 2 (each within the scatter of the next).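

For the compounds shown here, putting methyl in place of fluoro on an aromatic carbon, para to a large group, gives the only comparison so far of two compounds that differ in one place. In this assay, going by these compounds alone, the shared core and the rest of the molecule stay the same, and the step reads a number 7.1 percentage points lower from compound 3 to compound 4 (within the scatter), so at the single concentration tested this pair does not separate fluoro from methyl at this position. Nothing available explains the size of this step.

On these data alone, it remains open whether other groups in this place, such as an amine, a carboxylic acid or a longer chain, would give a value that stands clear of the scatter from compound 3 in this assay. As far as these compounds go, it is equally open whether methyl in place of fluoro would give a similar step with the other end of the molecule taken from compound 2, since a single pair cannot show whether the step carries over to a different partner.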